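Chain shortening at the succinimide-bearing carbon: compound 1 to compound 3

A few compounds are considered here, and "the series" means these few. Any claim that something is new, unique, unknown or untested is made for them only; others in the source may bear on it.

Compound 1 `CCC(C(=O)N1CCN(c2ccccc2)CC1)N1C(=O)CCC1=O` is the reference point of this pair. Among the compounds with values here, in a functional assay on the whole organism (strain Swiss) with Mus musculus as the target, in the maximal electroshock model, with a stated time of 0.25 h, at a dose of 300 mg/kg by the intraperitoneal route (a lower number here means a weaker effect, a higher number a stronger effect of the compound at the dose given), compound 1 gives 75%, the highest of the two numbers so far; its nearest neighbour, compound 2 `CCC(C(=O)N1CCN(c2ccccc2Cl)CC1)N1C(=O)CCC1=O`, gives 50% in this assay, and the step of a number 25 percentage points lower from compound 1 to compound 2 (beyond the scatter) is the only measured one. That step concerns chloro in place of hydrogen on an aromatic carbon and says nothing about the chain.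

Compound 3 `CC(C(=O)N1CCN(c2ccccc2)CC1)N1C(=O)CCC1=O` differs from compound 1 by hydrogen in place of methyl on a saturated chain carbon, two bonds along the chain from an amide-type nitrogen in a ring and a carbonyl carbon. Within the data shown here, no measured step bears on this change, so the expectation rests on compound 1 alone and is wide. Compound 3 is expected to remain active in this assay, with a step of about a number 10 percentage points lower from compound 1 to compound 3 (within the scatter) that may well lie within the scatter. The estimate for compound 3 in this assay is 65%, between 35% and 90%.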

Compound 3, a percentage reported as activity, at one dose (the size of the read-out at that dose, not a potency): 100%
For compound 3 the middle estimate is 35 percentage points below the measured one; the whole stated range lies below it.
By their numbers in this assay, from the lowest: compound 2; then compound 1; then compound 3.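

In this assay, the step of a number 25 percentage points higher from compound 1 to compound 3 (beyond the scatter) shows that this position is not silent: hydrogen in place of methyl on this saturated chain carbon moves the read-out beyond the scatter, and upward. Within the data shown here, the earlier step, a number 25 percentage points lower from compound 1 to compound 2 (beyond the scatter), concerned an aromatic carbon only, so this is the first measured change in the chain and the first measured step upward from compound 1. At this single dose, ethyl to methyl is favourable in this pair, but nothing measured here accounts for the step.

Open, from the compounds shown here alone, is how a propyl chain or a hydroxyl group on this same carbon would read in this assay. Also open, going by these compounds, is whether chloro in place of hydrogen on an aromatic carbon would lower the read-out on the core of compound 3 as it does on the core of compound 1.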